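Relocating the hydroxyl on the aryl group: cytotoxicity notes

The source may report more compounds than this note shows. Statements on the series, on what has been measured and on what is new or still open speak of the compounds shown alone.

Compound 1 `Oc1ccc(-c2cc(-c3cccs3)cc(-c3ccccc3O)n2)cc1` and compound 3 `Oc1cccc(-c2cc(-c3ccsc3)cc(-c3ccccc3O)n2)c1` both carry a 2-hydroxyphenyl group on the aromatic carbon next to the ring nitrogen; how their two cores differ otherwise is not broken down here. In a functional assay on HCT-15 cells (Homo sapiens) for cytotoxicity, read by CCK-8 assay (on this read-out higher numbers stand for weaker inhibition and lower numbers for stronger inhibition), compound 1 gives only a limit, > 50000 nM. Compound 3 likewise gives only a limit in this assay, > 50000 nM. Compound 2 `Oc1ccc(-c2cc(-c3cccs3)cc(-c3cccc(O)c3)n2)cc1` carries 3-hydroxyphenyl in place of 2-hydroxyphenyl on an aromatic carbon, and in this assay compound 2 gives 1770 nM. The step is an at least 28-fold lower number from compound 1 to compound 2 (1.45 log units; beyond the scatter); it can be stated only as a lower bound because of the limit of > 50000 nM in this assay, at which 2 of the 3 values shown sit.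

Compound 4 `Oc1cccc(-c2cc(-c3ccsc3)cc(-c3cccc(O)c3)n2)c1` has not been measured. It differs from compound 3 by the same kind of change, (3-hydroxyphenyl in place of 2-hydroxyphenyl on an aromatic carbon), though not the same one: around the place, the group in compound 1 sits meta to a 4-hydroxyphenyl group and meta to a thiophen-2-yl group, whereas in compound 3 it sits meta to a 3-hydroxyphenyl group and meta to a thiophen-3-yl group. With a single measured example of this change, and compound 3 at a limit, the expected step from compound 3 to compound 4 in this assay is put at an at least 12-fold lower number from compound 3 to compound 4 (1.09 log units; beyond the scatter), set beside an at least 28-fold lower number from compound 1 to compound 2 (1.45 log units; beyond the scatter) and resting on that one step alone. The value expected for compound 4 in this assay is 4000 nM, with the estimate ranging from 800 nM to 50000 nM. A further limit rather than a number remains a real possibility.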

Compound 4, half-maximal inhibitory concentration: 1630 nM
For compound 4 the middle estimate is 2.5-fold (0.39 log units) above the measured one; the measured number falls inside the stated range.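

On the second core the change repeats: in this assay the read-out shows an at least 30-fold lower number from compound 3 to compound 4 (1.48 log units; beyond the scatter), so 3-hydroxyphenyl in place of 2-hydroxyphenyl next to the ring nitrogen gives a large step toward stronger inhibition on both cores shown. Within these two cores, the direction of the step carries from one core to the other, while any comparison of its size stays unresolved: the same change on two cores in this assay, an at least 28-fold lower number (1.45 log units; beyond the scatter) from compound 1 to compound 2 and an at least 30-fold lower number (1.48 log units; beyond the scatter) from compound 3 to compound 4; the limit leaves it open whether they differ. Each step is only a lower bound and its true size is unknown, because the value at its starting end is a limit and not a number: the limit of > 50000 nM in this assay, at which 2 of the 4 values shown sit.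

The compounds shown leave open whether the hydroxyl on this phenyl group is needed at all, and whether an amine, a carboxylic acid or a methoxy group in its place would keep the lower numbers. Also open, from the compounds shown here alone, are the separate contributions of the thiophen-2-yl and thiophen-3-yl groups and of the 4-hydroxyphenyl and 3-hydroxyphenyl groups on the rest of the core, since the two cores differ in both places at once.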